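Working notes on three measured compounds and one pending

A few compounds are considered here, and "the series" means these few. Any claim that something is new, unique, unknown or untested is made for them only; others in the source may bear on it.

Measured compounds:
compound 1 `COc1cc(-c2cc(/C=C/C(=O)c3ccc(N)cc3)[nH]n2)cc(OC)c1OC`: -98%
compound 2 `COc1ccc(C(=O)/C=C/c2cc(-c3cc(OC)c(OC)c(OC)c3)n[nH]2)cc1OC`: -98%
compound 3 `COc1ccc(-c2cc(/C=C/C(=O)c3ccc(N)cc3)[nH]n2)cc1OC`: -98%

All three values come from a functional assay on HOP-62 cells (Homo sapiens) for cytotoxicity, read by sulforhodamine B assay, with a stated time of 48 h, tested at 100 uM; on this read-out higher numbers stand for a weaker effect at the one concentration tested and lower numbers for a stronger effect. In this assay compound 1 gives -98%, compound 2 gives -98% and compound 3 gives -98%; the three stand level with one another at the digits shown, so no order among them can be read from these numbers.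

Two single-point steps connect the measured compounds. From compound 3 to compound 1 the structural change is methoxy in place of hydrogen on an aromatic carbon, and the step is no change at the digits printed from compound 3 to compound 1 (within the scatter). From compound 1 to compound 2 the step is no change at the digits printed from compound 1 to compound 2 (within the scatter). The difference between the cores of compound 2 and compound 3 is not broken down here.

Compound 4 `COc1cc(C(=O)/C=C/c2cc(-c3cc(OC)c(OC)c(OC)c3)n[nH]2)cc(OC)c1OC` is not yet measured. It differs from compound 2 by methoxy in place of hydrogen on an aromatic carbon. The description of the place around this change reads word for word as for the change from compound 3 to compound 1, so the two are the same change made on a different starting compound.

For compound 4 the expected step from compound 2 is a number 1 percentage points higher from compound 2 to compound 4 (within the scatter), which rests on compound 3 and compound 1, where the same change gave no change at the digits printed from compound 3 to compound 1 (within the scatter). Compound 4 is therefore estimated at -97% in this assay. The estimate for compound 4 is expected to lie between -100% and -88%.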

Compound 4, a percentage reported as activity, at one concentration (the size of the read-out at that concentration, not a potency): -100%
Beside the measured number, compound 4's estimate is 3 percentage points above it; low and high end bracket the measured number.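

In this assay, methoxy in place of hydrogen on an aromatic carbon, here ortho to a methoxy group and meta to a large group, gives a step that reads as a number 2 percentage points lower from compound 2 to compound 4 (within the scatter). Set beside the earlier case, the same change shows no difference between the two cores that can be told apart: the same change on two cores in this assay, no change at the digits printed (within the scatter) from compound 3 to compound 1 and a number 2 percentage points lower (within the scatter) from compound 2 to compound 4, 2 percentage points apart, within the scatter of two such steps. This shows that, at the one concentration tested, the change carries from the core of compound 3 to the core of compound 2 with the read-out staying within the scatter on both; it does not show that the change is without effect on potency, as a read-out at one concentration is not a potency, and two cores do not establish a rule for the whole series.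

The compounds shown leave open whether a group other than methoxy at this place, such as a longer chain like butoxy, a carboxylic acid or a dimethylamino group, would also leave the read-out within the scatter. They also leave open whether testing at lower concentrations would separate compound 2 from compound 4, or compound 3 from compound 1.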